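Swapping a Branched Arm for Plain Phenyl on an Amide

The source may report more compounds than this note shows. Statements on the series, on what has been measured and on what is new or still open speak of the compounds shown alone.

This study follows a small family of aminothiazole guanidines tested in a functional assay on HEK293T cells for agonist activity at histamine H2 receptor (Homo sapiens), read by beta-arrestin recruitment; a higher number here means a larger maximal response, a lower number a smaller maximal response. Compound 1 `CCCCCCNC(=O)/N=C(\N)NC1CCc2nc(N)sc2C1` and compound 3 `CCCCCCNC(=O)/N=C(\N)Nc1cccc(-c2csc(N)n2)c1` belong to the series, but for compound 1 the outcome is "not determined" (no result reported) and for compound 3 it is likewise "not determined" (no result reported), so neither gives a number to lean on. The only result in hand comes from compound 2 `Cc1nc(N)sc1CCCN/C(N)=N/C(=O)N[C@@H](C)c1ccccc1`, which in this assay reaches 0.46, a response well short of what the reference agonist produces. With nothing else measured, compound 2 stands alone, neither high nor low against any neighbour.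

Compound 4 `Cc1nc(N)sc1CCCN/C(N)=N/C(=O)Nc1ccccc1` is compound 2 with one change: phenyl in place of 1-phenylethyl on an amide-type nitrogen. The stereocentre that marked compound 2 is gone, and the branched arm becomes a bare ring. No comparable swap has been measured here, so there is no direct guide to its effect. The expectation is that the change is modest, with the step from compound 2 to compound 4 expected to be a number 0.010 lower from compound 2 to compound 4 (within the scatter), small enough to sit within the usual scatter in either direction. On that basis compound 4 is expected to reach about 0.45 in this assay, most likely somewhere between 0.25 and 0.65.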

Compound 4, intrinsic activity: the largest response reached, as a fraction of the reference agonist's: 0.25
Compound 4: middle estimate off by 0.20, on the high side; the measured number falls inside the stated range.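

In this assay, for the compounds shown here, putting phenyl in place of 1-phenylethyl on the amide-type nitrogen gives a number 0.21 lower from compound 2 to compound 4 (beyond the scatter), the first step that can be read, since compound 1 and compound 3 carry no number, and it shows that the maximal response does respond to a change at this position. The aromatic ring of carbon stays in both compounds, so the difference lies in what surrounds it: the arm shrinks from 8 heavy atoms to 6 and loses its one defined stereocentre, and this single step cannot separate the loss of those atoms from the loss of the stereocentre. Nothing measured here explains why the response falls.

A benzyl group on the same nitrogen would keep an extra carbon without any stereocentre, so it could begin to pull those two changes apart, and the mirror-image form of 1-phenylethyl would test the stereocentre alone. From the compounds shown here alone, how a straight hexyl chain, as carried by compound 1 and compound 3, would perform on the core of compound 2 also remains open.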